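Swapping the side chain on a shared core

The compounds below may be only part of what the source reports. "The series", "measured", "known", "first", "only" and "open" are said of these compounds alone.

Three measured compounds share one core. Compound 1 `CC[C@@H](C)[C@H](NC(=O)c1cc2ccccc2cn1)C(=O)OCc1ccccc1` gives 185 nM in a functional assay on HeLa cells (Homo sapiens) for antiproliferative activity, read by MTT assay, with a stated time of 48 h; a lower number here means a stronger inhibitor, a higher number a weaker inhibitor. Compound 2 `O=C(C[C@@H]1CCCN1C(=O)c1cc2ccccc2cn1)OCc1ccccc1` gives 87.7 nM in this assay, and compound 3 `NCCCC[C@H](NC(=O)c1cc2ccccc2cn1)C(=O)OCc1ccccc1` gives 196 nM. Among these three numbers compound 1 stands second highest: compound 3 is its nearest neighbour, and compound 2 lies furthest away, beyond the scatter. The step of a 1.1-fold higher number from compound 1 to compound 3 (0.03 log units; within the scatter) shows that exchanging one side chain for another at this place barely moved the number. Compound 4 `O=C(C[C@H](NC(=O)c1cc2ccccc2cn1)C(=O)OCc1ccccc1)OCc1ccccc1` carries the change ((benzyloxycarbonyl)methyl in place of sec-butyl on a saturated chain carbon bound to an amide-type nitrogen and a carbonyl carbon). Going by the values given here, only the step from compound 1 to compound 3 bears on this exchange, and it stayed within the scatter, so compound 4 is expected to show a 1.1-fold lower number from compound 1 to compound 4 (0.04 log units; within the scatter), no step beyond the scatter. The estimate for compound 4 is 170 nM, with a range from 70 nM to 420 nM.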

Compound 4, half-maximal inhibitory concentration: 411 nM
For compound 4 the middle estimate is 2.4-fold (0.38 log units) below the measured one, and the stated range covers the measured number.
By their numbers in this assay, from the lowest: compound 2; then compounds 1 and 3 (each within the scatter of the next); then compound 4.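

This place is not indifferent to its side chain: (benzyloxycarbonyl)methyl gives a 2.2-fold higher number from compound 1 to compound 4 (0.35 log units; beyond the scatter) in this assay and a 2.1-fold higher number from compound 3 to compound 4 (0.32 log units; beyond the scatter) as well. Both steps are modest, yet they show what the exchange from compound 1 to compound 3 did not: a side chain here can shift the number. Nothing measured here gives a reason for the rise. On these data alone, whether the aromatic ring or the carbonyl of the entering group goes with the higher number stays open. A carboxylic acid or a plain benzyl group at this place would help tell the two apart.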